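The source may report more compounds than this note shows. Statements on the series, on what has been measured and on what is new or still open speak of the compounds shown alone.

- compound 1 `CCOC(=O)c1cc(CCCOc2ccc(-c3noc(C(F)(F)F)n3)cc2)on1`: > 100000 nM
- compound 2 `CN(C)C(=O)c1cc(CCCOc2ccc(-c3noc(C(F)(F)F)n3)cc2)on1`: 28000 nM
- compound 3 `CNC(=O)c1cc(CCCOc2ccc(-c3noc(C(F)(F)F)n3)cc2C(F)(F)F)on1`: > 100000 nM

In an ADME assay on HeLa cells (Homo sapiens) for cytotoxicity, read by crystal violet staining, with a stated time of 72 h (a lower number here means that less compound is tolerated, a higher number that more compound is tolerated), compound 1 gives > 100000 nM, which is a limit and not a number. Compound 1 therefore stands at the limit of > 100000 nM in this assay, at which 2 of the 3 values shown sit.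

Compound 4 `CCOC(=O)c1cc(CCCOc2ccc(-c3noc(C(F)(F)F)n3)cc2N)on1` keeps the ethoxy on the carbonyl carbon and changes the core of compound 1 at one place: amino in place of hydrogen on an aromatic carbon. This puts amino in place of hydrogen on an aromatic carbon, ortho to a large group.

Within the data shown here, the only measured step is an at least 3.5-fold lower number from compound 1 to compound 2 (0.55 log units; beyond the scatter). That step lies at the carbonyl carbon and not on the aromatic ring, so it gives a scale for one change in this series and no direct read on amino. Compound 3, which carries a trifluoromethyl group on the same six-membered aromatic ring, gives > 100000 nM, and this too is a limit.

On compound 2 at 28000 nM, a step toward a lower number of modest size is expected at most, and none beyond the scatter remains quite possible. The expected step is an at least 1.4-fold lower number from compound 1 to compound 4 (0.15 log units; that floor lies within the scatter). For compound 4 the estimated value is 70000 nM, with an expected range from 25000 nM to 100000 nM.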

Compound 4, half-maximal cytotoxic concentration: > 100000 nM
Compound 4 gave a limit, no number; the forecaster's own chance of this, stated with the estimate: 50%; at least 1.4-fold (0.15 log units) between middle value and limit.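

In this assay compound 4 gives > 100000 nM as a limit and not a number. Among these compounds, compound 1 also stands at a limit, so no step between compound 1 and compound 4 can be read: the limit of > 100000 nM in this assay, at which 3 of the 4 values shown sit. The compounds shown leave open whether amino in place of hydrogen on an aromatic carbon shifts the number in this assay at all.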